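The source may report more compounds than this note shows. Statements on the series, on what has been measured and on what is new or still open speak of the compounds shown alone.

In a functional assay on L1210 cells (Mus musculus) for inhibition, read by cell counting, with a stated time of 2 days (a lower number here means a stronger inhibitor, a higher number a weaker inhibitor), three compounds built on two related cores have been measured. Compound 1 `C=C(Br)C(=O)Nc1cccc(-c2cn3nc(Cc4ccccc4)sc3n2)c1` gives 3000 nM. Compound 2 `C=C(Br)C(=O)Nc1cccc(-c2cn3nc(Cc4ccc(Cl)cc4)sc3n2)c1` carries chloro in place of hydrogen on an aromatic carbon and gives 2300 nM; the step of a 1.3-fold lower number from compound 1 to compound 2 (0.12 log units; within the scatter) is small. Compound 3 `C=C(Br)C(=O)Nc1cccc(-c2cn3c(-c4ccccc4)csc3n2)c1` rests on a different core, and the difference between the two cores is not broken down here; compound 3 gives 1300 nM, the lowest number of the three, though its values against compound 2 lie within the scatter, and only against compound 1 is the gap beyond it.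

Compound 4 `C=C(Br)C(=O)Nc1cccc(-c2cn3c(-c4ccc(Cl)cc4)csc3n2)c1` has not yet been measured. It differs from compound 3 by chloro in place of hydrogen on an aromatic carbon, the same kind of change as from compound 1 to compound 2, at the same kind of place, here on a phenyl rather than a benzyl. Since the step of a 1.3-fold lower number from compound 1 to compound 2 (0.12 log units; within the scatter) stayed within the scatter, the step of a 1.3-fold lower number from compound 3 to compound 4 (0.11 log units; within the scatter) is expected to be similarly small, resting only on that single earlier pair. Compound 4 is therefore estimated at 1000 nM, between 450 nM and 2200 nM.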

Compound 4, half-maximal inhibitory concentration: 1900 nM
Compound 4: the middle estimate sits 1.9-fold (0.28 log units) below what was measured, within the range that was stated.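

In this assay, chloro in place of hydrogen on an aromatic carbon of the phenyl gives a 1.5-fold higher number from compound 3 to compound 4 (0.16 log units; within the scatter), so the step on this second core is again small. Set beside the earlier step, it cannot be told apart from it: the same change on two cores in this assay, a 1.3-fold lower number (0.12 log units; within the scatter) from compound 1 to compound 2 and a 1.5-fold higher number (0.16 log units; within the scatter) from compound 3 to compound 4, 1.9-fold (0.28 log units) apart, within the scatter of two such steps. This shows that, across these two pairs, the change leaves the number within the scatter on both cores, but it shows no direction for the change, and two pairs give no rule for any further core.

The compounds shown leave open whether a group other than chloro at this place, such as methoxy, a nitrile or an amine, would move the number beyond the scatter on either core. They also leave open what a carboxylic acid or a longer chain in place of the phenyl or benzyl would do.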